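This account rests on a few compounds, and the source may have more. Where it says the series, first, only, none or still open, it means among the compounds named here.

Measured so far in a physicochemical assay for solubility, read by HPLC, in phosphate buffer, measured as thermodynamic solubility, with a stated time of 48 h, at pH 7.2; a higher number here means a more soluble compound, a lower number a less soluble compound:

Compound 1, `CCCOc1ccc(C[C@@H](Cc2ccccc2)C(=O)O)cc1CNC(=O)c1ccc(-c2cccnc2)cc1`, gives 69.5 ug/mL in this assay.
Compound 2, `CCCOc1ccc(C[C@@H](Cc2ccccc2)C(=O)O)cc1CNC(=O)c1ccc(-c2ccc(F)cc2)cc1`, gives in this assay only a limit of the assay, < 1 ug/mL, and no number.
Compound 3, `CCCOc1ccc(C[C@@H](Cc2ccccc2)C(=O)O)cc1CNC(=O)c1ccc(-c2cnccn2)cc1`, gives 32.2 ug/mL in this assay.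

Compound 1 stands at the highest of the two numbers; the nearest is compound 3, a modest distance away, a 2.2-fold lower number from compound 1 to compound 3 (0.33 log units; beyond the scatter). Compound 4, `CCCOc1ccc(C[C@@H](Cc2ccccc2)C(=O)O)cc1CNC(=O)c1ccc(-c2cccc(F)c2)cc1`, has not yet been measured. It differs from compound 1 by 3-fluorophenyl in place of pyridin-3-yl on an aromatic carbon.

The step that bears on this change is an at least 69-fold lower number from compound 1 to compound 2 (1.84 log units; beyond the scatter), where a 4-fluorophenyl replaced the same pyridin-3-yl and the value dropped to the limit of < 1 ug/mL in this assay, at which 1 of the 3 values shown sits. A 3-fluorophenyl is a closely related fluorophenyl, so a large fall is expected for compound 4, a 58-fold lower number from compound 1 to compound 4 (1.76 log units; beyond the scatter), and the result may again be only a limit.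

The expected value for compound 4 in this assay is 1.2 ug/mL, with a likely range from 0.3 ug/mL to 5 ug/mL.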

Compound 4, solubility: < 1 ug/mL
Compound 4: no number, only a limit (the forecaster's own chance of this, stated with the estimate: 55%); middle value at least 1.2-fold (0.07 log units) away from the limit.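

With 3-fluorophenyl as with 4-fluorophenyl at this position, the result in this assay is no number but a limit, so the fall is not peculiar to a single fluorophenyl: the limit of < 1 ug/mL in this assay, at which 2 of the 4 values shown sit.

Against the compounds with a nitrogen in this ring the fall is large, an at least 69-fold lower number from compound 1 to compound 4 (1.84 log units; beyond the scatter), and likewise an at least 32-fold lower number from compound 3 to compound 4 (1.50 log units; beyond the scatter); among the four compounds shown, only those with a nitrogen in the ring give a number, and none goes against this. As far as these compounds go, the step between compound 2 and compound 4 joins two limits and cannot be read, so the order of these two fluorophenyl compounds stays unknown.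

From the compounds shown here alone, it remains open whether an unsubstituted phenyl would also sit at the limit, which would separate the part played by the fluorine from that of the missing ring nitrogen. Going by these compounds, it is also open whether a phenyl ring carrying an amine would return a number.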